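The source may report more compounds than this note shows. Statements on the series, on what has been measured and on what is new or still open speak of the compounds shown alone.

Going by the values given here, compound 3 `Cc1ccc(S(=O)(=O)NCc2cn(C[C@H](O)[C@H]3OC(=O)C(OCc4ccccc4)=C3OCc3ccccc3)nn2)cc1` gives the lowest number of the two numbers so far in an ADME assay on HFF cells (Homo sapiens) for cytotoxicity, read by MTT assay, with a stated time of 72 h; a lower number here means a stronger inhibitor, a higher number a weaker inhibitor: compound 3 shows 50 nM. Compound 1 `O=C1O[C@H]([C@@H](O)Cn2cc(-c3ccc(Br)cc3)nn2)C(OCc2ccccc2)=C1OCc1ccccc1` gives 5100 nM in this assay, a step described by a 100-fold lower number from compound 1 to compound 3 (2.01 log units; beyond the scatter). Compound 2 `Cc1ccc(-c2cn(C[C@H](O)[C@H]3OC(=O)C(OCc4ccccc4)=C3OCc3ccccc3)nn2)cc1` reaches only a limit of this assay, > 100000 nM, and so is known through (the limit of > 100000 nM in this assay, at which 1 of the 3 values shown sits). Compound 4 `COc1ccc(-c2cn(C[C@H](O)[C@H]3OC(=O)C(OCc4ccccc4)=C3OCc3ccccc3)nn2)cc1` differs from compound 3 by 4-methoxyphenyl in place of (((4-methylphenyl)sulfonyl)amino)methyl on an aromatic carbon. Both measured steps that swap an aryl group for the sulfonamide-bearing chain, a 100-fold lower number from compound 1 to compound 3 (2.01 log units; beyond the scatter) and an at least 2000-fold lower number from compound 2 to compound 3 (3.30 log units; beyond the scatter), were large, and the reverse direction is taken here; compound 1 and compound 2 also differ by an at least 19-fold higher number from compound 1 to compound 2 (1.29 log units; beyond the scatter) through a ring substituent alone. For compound 4 a large rise is therefore expected, an 800-fold higher number from compound 3 to compound 4 (2.90 log units; beyond the scatter), with an estimate of 40000 nM in a range from 5000 nM to 200000 nM.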

Compound 4, half-maximal inhibitory concentration: < 10 nM
Compound 4 was reported as a limit (the forecaster's own chance of this, stated with the estimate: 45%); at least 4000-fold (3.60 log units) between middle value and limit.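

In this assay, the (((4-methylphenyl)sulfonyl)amino)methyl chain is not needed for a low number at this position: 4-methoxyphenyl gives an at least 5.0-fold lower number from compound 3 to compound 4 (0.69 log units; beyond the scatter). The outcome with an aryl group here turns on its ring substituent alone: methoxy in place of methyl gives an at least 10000-fold lower number from compound 2 to compound 4 (4.00 log units; beyond the scatter), and methoxy in place of bromo gives an at least 510-fold lower number from compound 1 to compound 4 (2.70 log units; beyond the scatter). Compound 4 is known only as a limit: the limit of < 10 nM in this assay, at which 1 of the 4 values shown sits.

The compounds shown leave open whether an amine or a carboxylic acid in place of the methoxy would keep so low a number.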